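The source may hold more compounds than are shown below. What is called first, only, known or untested is meant among the compounds shown, and "the series" means these compounds.

Going by the values given here, in a functional assay on MCF7 cells (Homo sapiens) for inhibition, in the presence of a further agent that is not named here (a higher number here means a weaker inhibitor, a lower number a stronger inhibitor), compound 1 `Nc1ccc(-c2cc(=O)c3c(N)ccc(F)c3o2)cc1` gives 170 nM, the higher of the two numbers so far, and compound 2 `Nc1ccc(-c2cc(=O)c3c(N)c(F)cc(F)c3o2)cc1` gives 46 nM. Compound 3 `Nc1ccc(-c2cc(=O)c3c(N)ccc(O)c3o2)cc1` has not yet been measured. Its difference from compound 1 is hydroxy in place of fluoro on an aromatic carbon, which amounts to hydroxy in place of fluoro on an aromatic carbon, para to an amino group. Among the compounds with values here, the only measured step, a 3.7-fold lower number from compound 1 to compound 2 (0.57 log units; beyond the scatter), adds a fluoro at another aromatic carbon and keeps the fluoro that compound 3 lacks, so it bears only indirectly. Within the data shown here, it shows a modest shift from one change on the shared core, but no measured step replaces this fluoro, and the direction remains uncertain. A modest rise in this assay is expected, though a result within the scatter would not surprise. The estimated step is a 1.8-fold higher number from compound 1 to compound 3 (0.25 log units; within the scatter). For compound 3 the expected value is 300 nM, with an estimated range of 60 nM to 1500 nM.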

Compound 3, half-maximal inhibitory concentration: 16000 nM
Beside the measured number, compound 3's estimate is 53-fold (1.73 log units) below it; measured number outside the range, above it.
By their numbers in this assay, from the lowest: compound 2; then compound 1; then compound 3.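

In this assay, hydroxy in place of fluoro on the aromatic carbon para to an amino group gives the largest change seen in the series (a 94-fold higher number from compound 1 to compound 3 (1.97 log units; beyond the scatter)). This is the only measured replacement at this position, and it shows that the position is highly sensitive to a swap of one heavy atom. The step also far exceeds the one produced by adding a fluoro elsewhere on the shared core (a 3.7-fold lower number from compound 1 to compound 2 (0.57 log units; beyond the scatter)). No supporting data on the compounds bear on the origin of this large step.

As far as these compounds go, whether the loss is specific to hydroxy or follows any departure from fluoro remains open, and a methoxy or chloro group at this position would help separate the two readings. From the compounds shown here alone, it is also open whether the additional fluoro of compound 2 would offset the change to hydroxy.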